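Hydrazone aryl swap: indole to phenyl

A few compounds are considered here, and "the series" means these few. Any claim that something is new, unique, unknown or untested is made for them only; others in the source may bear on it.

The series shares one core; compound 1 `CN(C)CCn1cnnc1-c1cc(Oc2ccc(NC(=O)N/N=C/c3c[nH]c4ccccc34)cc2F)ccn1` carries a 1H-indol-3-yl on the carbon with a double bond to nitrogen. In a functional assay on U-87MG ATCC cells (Homo sapiens) for cytotoxicity, read by MTT assay, with a stated time of 72 h (a lower number here means a stronger inhibitor, a higher number a weaker inhibitor), compound 1 gives 690 nM, the lowest number of the three measured. Compound 2 `COc1ccc(/C=N/NC(=O)Nc2ccc(Oc3ccnc(-c4nncn4CCN(C)C)c3)c(F)c2)c(OC)c1` gives 12600 nM and compound 3 `COc1ccc(/C=N/NC(=O)Nc2ccc(Oc3ccnc(-c4nncn4CCN(C)C)c3)c(F)c2)c(OC)c1OC` gives 7650 nM; the steps of an 18-fold higher number from compound 1 to compound 2 (1.26 log units; beyond the scatter) and an 11-fold higher number from compound 1 to compound 3 (1.04 log units; beyond the scatter) are both large, whereas a 1.6-fold lower number from compound 2 to compound 3 (0.22 log units; within the scatter) is not. Compound 4 `CN(C)CCn1cnnc1-c1cc(Oc2ccc(NC(=O)N/N=C/c3ccccc3)cc2F)ccn1` differs from compound 1 by phenyl in place of 1H-indol-3-yl on a carbon with a double bond to nitrogen. Both measured aryl replacements at this carbon raised the number sharply, so a large upward step in this assay is expected here as well; the expected step is an 8.7-fold higher number from compound 1 to compound 4 (0.94 log units; beyond the scatter). Compound 4 is accordingly estimated at 6000 nM, within 2000 nM to 20000 nM.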

Compound 4, half-maximal inhibitory concentration: 2250 nM
For compound 4 the middle estimate is 2.7-fold (0.43 log units) above the measured one; the measured number falls inside the stated range.
By their numbers in this assay, from the lowest: compound 1; then compound 4; then compounds 3 and 2 (each within the scatter of the next).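

Plain phenyl on this carbon gives only a modest loss against 1H-indol-3-yl, with a 3.3-fold higher number from compound 1 to compound 4 (0.51 log units; beyond the scatter) as the step, so the bicyclic group is not essential for a number in this range. The methoxy-bearing phenyls are the poorer replacements, as shown by a 3.4-fold lower number from compound 3 to compound 4 (0.53 log units; beyond the scatter) and by a 5.6-fold lower number from compound 2 to compound 4 (0.75 log units; beyond the scatter) in the same direction. Nothing available explains these differences.

Still open, on these data alone, is whether a single methoxy, a hydroxyl or an amine on the phenyl already raises the number, and whether a methyl on the indole nitrogen keeps the advantage of compound 1.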